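The compounds below may be only part of what the source reports. "The series", "measured", "known", "first", "only" and "open" are said of these compounds alone.

Measured compounds:
Compound 1 `CC1=NN(C(=O)COc2ccc(Cl)cc2)C(c2ccccc2O)C1`: in a functional assay on PC-3 cells (Homo sapiens) for cytotoxicity, read by MTT assay, with a stated time of 48 h (a higher number here means a weaker inhibitor, a lower number a stronger inhibitor), compound 1 gives 38800 nM.
Compound 2 `CCN(CC)CC(=O)N1N=C(C)CC1c1ccccc1O`: compound 2 gives 25900 nM.
Compound 3 `CC1=NN(C(=O)CN2CCC(Cl)CC2)C(c2ccccc2O)C1`: compound 3 gives 34800 nM.

Compound 2 has the lowest number of the three, but this says little: the steps of a 1.5-fold lower number from compound 1 to compound 2 (0.18 log units; within the scatter) and a 1.3-fold higher number from compound 2 to compound 3 (0.13 log units; within the scatter) both lie within the scatter, as does a 1.1-fold lower number from compound 1 to compound 3 (0.05 log units; within the scatter), so the three compounds cannot be told apart by these numbers.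

Compound 4 `CCN(CC)CC(=O)N1N=C(C)CC1c1ccccc1OC(C)=O` is the next step from compound 2. The change is acetyl in place of hydrogen on an oxygen on an aromatic ring; the core and the diethylamino chain stay as they are. Going by the values given here, none of the measured steps touches this oxygen: all three vary the group on the saturated chain carbon bound to the carbonyl carbon, and every one of them stayed within the scatter. Among the compounds with values here, there is thus no direct guide to what the acetyl brings, only the observation that the whole series so far sits in one narrow band. The expectation is therefore a step of a 1.1-fold higher number from compound 2 to compound 4 (0.03 log units; within the scatter), that is no change beyond the scatter, with a wide allowance for the unknown. Compound 4 is expected to give about 28000 nM in this assay, within a range from 9000 nM to 90000 nM.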

Compound 4, half-maximal inhibitory concentration: 51200 nM
Estimate against measurement, compound 4: 1.8-fold (0.26 log units) below, within the range that was stated.
By their numbers in this assay, from the lowest: compounds 2, 3, 1 and 4 (each within the scatter of the next).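

Going by these compounds alone, the oxygen on the aromatic ring is changed here for the first time, and going from hydroxy to acetoxy gives (a 2.0-fold higher number from compound 2 to compound 4 (0.30 log units; within the scatter)) in this assay. So the hydrogen on this oxygen can be replaced by acetyl without a difference that these numbers can separate from the scatter of repeated measurements, and a change at this oxygen joins the changes on the chain in leaving the compounds indistinguishable. This single pair cannot show whether the hydroxy group matters in general, and no measurement is available to explain the result.

What the compounds shown leave open is whether a different group on this oxygen, such as a methyl group, a benzoyl group or a longer acyl chain, would move the number clearly beyond the scatter, or whether an amine in place of the hydroxy group would do so. On these data alone, it is also open whether acetyl on this oxygen would give a similar step when the diethylamino group is replaced by 4-chlorophenoxy or 4-chloropiperidin-1-yl.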